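The compounds below may be only part of what the source reports. "The series", "measured", "known", "first", "only" and "open" are said of these compounds alone.

Measured in a functional assay on the whole organism for inhibition, with Nicotiana tabacum as the target; on this read-out higher numbers stand for weaker inhibition and lower numbers for stronger inhibition:
compound 1 `Cc1nc(Nc2ccc(I)cc2)c2cc[nH]c2n1` gives 219000000 nM
compound 2 `CC(=O)c1ccc(Nc2[nH]c(C)nc3nccc2-3)cc1` gives 646000000 nM
compound 3 `CCC(C)Nc1[nH]c(C)nc2nccc1-2` gives 174000000 nM

Compound 3 carries the smallest of the three numbers, but its reading and that of compound 1 lie within the usual scatter of each other, so the two cannot be told apart on this assay. Compound 2 sits clearly apart: its number is beyond the scatter above that of compound 3, and it is the only one of the three that is.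

Compound 4 `Cc1nc2nccc-2c(NCC(C)C)[nH]1` is the next member. It differs from compound 3 in one place: isobutyl in place of sec-butyl on a nitrogen on an aromatic ring. The two compounds hold the same atoms, joined differently, and the change goes no further than the shape of that chain.

Among the measured compounds shown here, no pair of measured compounds covers a change of this kind, so there is no step in this assay to lean on. A rearrangement of the same atoms on the same nitrogen, with no ring, no donor and no acceptor entering or leaving, is expected to give a step that stays within the scatter, in either direction. The expected step is a 1.0-fold higher number from compound 3 to compound 4 (0.01 log units; within the scatter). Compound 4 is therefore expected to give about 180000000 nM in this assay, within a range from 60000000 nM to 550000000 nM.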

Compound 4, half-maximal inhibitory concentration: 38900000 nM
The estimate for compound 4 lay 4.6-fold (0.67 log units) above the measured number; the measured number lies below the stated range.
By their numbers in this assay, from the lowest: compound 4; then compounds 3 and 1 (each within the scatter of the next); then compound 2.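

In this assay the way the chain is joined matters at this position: isobutyl in place of sec-butyl on a nitrogen on an aromatic ring gives a 4.5-fold lower number from compound 3 to compound 4 (0.65 log units; beyond the scatter) with the same atoms in both compounds, and with no ring, donor or acceptor entering or leaving. Among the compounds shown here, the earlier compounds included no pair differing in one place, so this is the first sign that the series responds to a change at this nitrogen, and here a rearrangement of the chain alone is enough to take the step beyond the scatter. It remains a single, modest step from one pair, and nothing at hand bears on its origin.

Still open, as far as these compounds go, is whether the lower number belongs to isobutyl in particular or would also appear with an unbranched butyl chain, a longer chain such as pentyl, or a cyclopropylmethyl group on the same nitrogen. Also open, from the compounds shown here alone, is how the chain tolerates an added amine or carboxylic acid at its end, and whether the same exchange gives a step of similar size on other members.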